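This account rests on a few compounds, and the source may have more. Where it says the series, first, only, none or still open, it means among the compounds named here.

In a toxicity assay on cells (Fibroblast, Homo sapiens) for cytotoxicity (on this read-out higher numbers stand for weaker inhibition and lower numbers for stronger inhibition), compound 2 `COc1cccc(C(=O)OC/C=C(C)/C=C/C=C(C)/C=C/C2=CCCCC2(C)C)c1O` gives 27000 nM and compound 1 `CC(/C=C/C1=CCCCC1(C)C)=C\C=C\C(C)=C\COC(=O)c1cc(O)c(O)c(O)c1` gives 35000 nM, so the two values lie within the scatter of each other. Compound 3 `COc1ccc(O)c(C(=O)OC/C=C(C)/C=C/C=C(C)/C=C/C2=CCCCC2(C)C)c1` is reached from compound 2 through (2-hydroxy-5-methoxyphenyl in place of 2-hydroxy-3-methoxyphenyl on a carbonyl carbon). Going by the values given here, the only measured step bearing on this change at the same carbonyl carbon is a 1.3-fold lower number from compound 1 to compound 2 (0.11 log units; within the scatter), which stays within the scatter. No step beyond the scatter is therefore expected in this assay. The expected step is a 1.0-fold higher number from compound 2 to compound 3 (0.02 log units; within the scatter). For compound 3 the estimated value is 28000 nM, with an expected range of 14000 nM to 55000 nM.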

Compound 3, half-maximal inhibitory concentration: 570000 nM
For compound 3 the middle estimate is 20-fold (1.31 log units) below the measured one, and the stated range ends below it.
By their numbers in this assay, from the lowest: compounds 2 and 1 (each within the scatter of the next); then compound 3.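

In this assay, 2-hydroxy-5-methoxyphenyl in place of 2-hydroxy-3-methoxyphenyl on the carbonyl carbon gives a 21-fold higher number from compound 2 to compound 3 (1.32 log units; beyond the scatter), although both groups hold the same atoms, joined differently. This place therefore responds to the arrangement of the ring groups, which the earlier pair, within the scatter of each other, did not show, and the same group in place of 3,4,5-trihydroxyphenyl gives a 16-fold higher number from compound 1 to compound 3 (1.21 log units; beyond the scatter). No available evidence bears on the origin of this step. Open, on these data alone, is how an amine or a carboxylic acid on the ring would read at this place.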